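The source may report more compounds than this note shows. Statements on the series, on what has been measured and on what is new or still open speak of the compounds shown alone.

Compound 2 `CC(=O)N1CCN(S(=O)(=O)CCCN2CCC(CNC(=O)c3cccc4c3OCCO4)CC2)CC1` and compound 1 `CCN1CCN(S(=O)(=O)CCCN2CCC(CNC(=O)c3cccc4c3OCCO4)CC2)CC1` differ only at one ring nitrogen. In an assay on isolated protein for inhibition of 5-hydroxytryptamine receptor 4 (Homo sapiens) (a lower number here means a stronger inhibitor, a higher number a weaker inhibitor), compound 1 gives 0.0501 nM, while compound 2 gives 0.126 nM, the higher of the two numbers; the step of a 2.5-fold higher number from compound 1 to compound 2 (0.40 log units; beyond the scatter) is the only measured one that bears here. Compound 3 `O=C(NCC1CCN(CCCS(=O)(=O)N2CCN(C3CCCC3)CC2)CC1)c1cccc2c1OCCO2` is not yet measured and carries cyclopentyl in place of acetyl on an amine nitrogen in a ring. Since that step returns an alkyl group to the same nitrogen, compound 3 is expected to move back toward compound 1, an estimated 2.1-fold lower number from compound 2 to compound 3 (0.32 log units; beyond the scatter). The expected value for compound 3 is 0.06 nM, within 0.02 nM to 0.2 nM.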

Compound 3, inhibition constant: 0.0159 nM
Compound 3: the middle estimate sits 3.8-fold (0.58 log units) above what was measured, outside the stated range (below it).
By their numbers in this assay, from the lowest: compound 3; then compound 1; then compound 2.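

With cyclopentyl on this ring nitrogen, this assay shows a 7.9-fold lower number from compound 2 to compound 3 (0.90 log units; beyond the scatter) and also a 3.2-fold lower number from compound 1 to compound 3 (0.50 log units; beyond the scatter) as well, so this position separates two alkyl groups and not only alkyl from acetyl. Across these three compounds the numbers fall from acetyl through ethyl to cyclopentyl. No measured evidence here explains this order. From the compounds shown here alone, whether a cyclohexyl or benzyl group on the same nitrogen would lower the number further remains open, and three compounds cannot show whether the order extends beyond these groups.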